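Swapping a thiophene for cyclopentyl on a chromone core

The source may hold more compounds than are shown below. What is called first, only, known or untested is meant among the compounds shown, and "the series" means these compounds.

Measured compounds:
compound 1, `CN(C)CCCCCCCCCOc1ccc2oc(-c3ccccc3)cc(=O)c2c1`, 334 nM
compound 2, `O=c1cc(-c2cccs2)oc2ccc(OCCCCCCN3CCC(O)CC3)cc12`, 119 nM

In an assay on isolated protein (Cavia porcellus) with Sigma non-opioid intracellular receptor 1 (Homo sapiens) as the target, read by radioligand binding (a lower number here means a stronger inhibitor, a higher number a weaker inhibitor), compound 2 gives the lower of the two numbers, and its gap to compound 1 lies beyond the usual scatter. Compound 3, `O=c1cc(C2CCCC2)oc2ccc(OCCCCCCN3CCC(O)CC3)cc12`, has not yet been measured. It differs from compound 2 in one place: cyclopentyl in place of thiophen-2-yl on an aromatic carbon. Going by the values given here, no measured pair shows this exact change, so the expectation rests on the pair above alone. A modest weakening is expected, a 2.1-fold higher number from compound 2 to compound 3 (0.32 log units; beyond the scatter), since the five-membered aromatic ring is replaced by a carbon-only ring. Compound 3 is therefore estimated at 250 nM, within a range of 80 nM to 800 nM.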

Compound 3, half-maximal inhibitory concentration: 51 nM
Estimate against measurement, compound 3: 4.9-fold (0.69 log units) above, and the stated range ends above it.
By their numbers in this assay, from the lowest: compound 3; then compound 2; then compound 1.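

In this assay, an aromatic ring is not required on this aromatic carbon next to the ring oxygen: cyclopentyl in place of thiophen-2-yl gives a 2.3-fold lower number from compound 2 to compound 3 (0.37 log units; beyond the scatter) and a stronger inhibitor. A ring of carbon only, without the sulfur and its hydrogen-bond acceptor count, is therefore tolerated here and even preferred in this pair. Nothing available explains why the number falls. Going by these compounds, whether cyclohexyl or an open-chain isopropyl group would do better at this position remains open, as does whether the same swap would hold with a different amine at the end of the chain.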